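Mirror-image forms of a diacylglycerol lipase-alpha inhibitor

A few compounds are considered here, and "the series" means these few. Any claim that something is new, unique, unknown or untested is made for them only; others in the source may bear on it.

Measured so far:
compound 1 `O=C(N1CCCC[C@@H]1COCc1ccccc1)n1cc(-c2ccc(-c3ccccc3)cc2)nn1` gives 79.4 nM
compound 2 `O=C(N1CCC=C[C@@H]1Cc1ccccc1)n1cc(-c2ccc(-c3ccccc3)cc2)nn1` gives 0.794 nM

Of the compounds shown here, two have been measured in an assay on HEK293 cells for inhibition of diacylglycerol lipase-alpha (Homo sapiens), read by colorimetric assay, with stated times of 30 min, 60 s and 20 min; on this read-out higher numbers stand for weaker inhibition and lower numbers for stronger inhibition. Compound 1 has the structure `O=C(N1CCCC[C@@H]1COCc1ccccc1)n1cc(-c2ccc(-c3ccccc3)cc2)nn1` and in this assay compound 1 gives 79.4 nM. Compound 2 has the structure `O=C(N1CCC=C[C@@H]1Cc1ccccc1)n1cc(-c2ccc(-c3ccccc3)cc2)nn1` and in this assay compound 2 gives 0.794 nM. Among these two numbers compound 2 stands lowest, and the gap to compound 1 lies well beyond the usual scatter, so compound 2 is the stronger inhibitor of the pair. Because the two structures differ in more than one place, nothing further is drawn from that gap.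

Compound 3 has the structure `O=C(N1CCC=C[C@H]1Cc1ccccc1)n1cc(-c2ccc(-c3ccccc3)cc2)nn1`. Compared with compound 2, (the two compounds have the same atoms and bonds and differ only in configuration as drawn: 1 of 1 stereo elements differ; a stereocentre at a saturated ring carbon is drawn S in compound 2 and R in compound 3); the two compounds are mirror images of each other at that one centre. Within the data shown here, no measured pair in this set shows what such a change does. In many enzyme assays the two mirror-image forms of a compound do not inhibit equally, and the form already measured is very potent, so compound 3 is expected to give a weaker result, with a step of a 10-fold higher number from compound 2 to compound 3 (1.00 log units; beyond the scatter) that is estimated to exceed the scatter. Compound 3 is therefore expected to give about 8 nM in this assay, estimated to lie between 1.2 nM and 60 nM.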

Compound 3, half-maximal inhibitory concentration: 79.4 nM
For compound 3 the middle estimate is 9.9-fold (1.00 log units) below the measured one, and the stated range ends below it.
By their numbers in this assay, from the lowest: compound 2; then compounds 1 and 3 (each within the scatter of the next).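

Among these compounds, this pair gives the first clean comparison in the set, as the earlier compounds differ in more than one place. In this assay, switching the stereocentre at a saturated ring carbon from S to R brings a 100-fold higher number from compound 2 to compound 3 (2.00 log units; beyond the scatter), a large step. The spatial arrangement at this single centre therefore matters greatly for inhibition, with the S form as drawn being the stronger inhibitor, and the whole gap can be assigned to configuration because nothing else separates the two structures: the fact that compounds 2 and 3 differ only in the configuration as drawn

The compounds shown leave open why the mirror-image forms differ so widely, and whether the S form would keep its advantage on the core of compound 1 or with other groups on the same core. As far as these compounds go, it also remains open how the number would move if an amine, a carboxylic acid or a longer chain stood in place of the phenyl group at the far end of the molecule, and whether the preference for one mirror-image form would survive such a change.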